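The source may hold more compounds than are shown below. What is called first, only, known or untested is meant among the compounds shown, and "the series" means these compounds.

Three compounds of the series, differing only in the aryl group on the shared core, have been measured in a functional assay on BJAB cells (Homo sapiens) for antiproliferative activity, with a stated time of 4 days; on this read-out lower numbers stand for an effect already at smaller amounts and higher numbers for an effect only at larger amounts of compound. Compound 1 `Cc1ccc(-c2c(C)nn(-c3nc(-c4ccc(Cl)c(Cl)c4)c(SC(C)C)s3)c2C(=O)O)cc1` gives 3800 nM. Compound 2 `Cc1ccccc1-c1c(C)nn(-c2nc(-c3ccc(Cl)c(Cl)c3)c(SC(C)C)s2)c1C(=O)O` gives 5500 nM, and compound 3 `Cc1nn(-c2nc(-c3ccc(Cl)c(Cl)c3)c(SC(C)C)s2)c(C(=O)O)c1-c1cccc(Cl)c1C` gives 5100 nM. The steps between them are small: a 1.4-fold higher number from compound 1 to compound 2 (0.16 log units; within the scatter); a 1.3-fold higher number from compound 1 to compound 3 (0.13 log units; within the scatter); a 1.1-fold lower number from compound 2 to compound 3 (0.03 log units; within the scatter). Compound 3 therefore sits among three numbers that are all within the scatter of one another, with compound 2 nearest and compound 1 furthest.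

Compound 4 `Cc1nn(-c2nc(-c3ccc(Cl)c(Cl)c3)c(SC(C)C)s2)c(C(=O)O)c1-c1ccccc1[N+](=O)[O-]` differs from compound 3 in one place: 2-nitrophenyl in place of 3-chloro-2-methylphenyl on an aromatic carbon. Going by the values given here, no measured step exchanges an aryl group for one bearing a nitro group, so none bears directly on this change. The closest comparisons are the three aryl exchanges already made, each of which remained within the scatter. On that basis no step beyond the scatter is expected in this assay, in either direction. The estimated step is a 1.0-fold lower number from compound 3 to compound 4 (0.01 log units; within the scatter). Compound 4 is accordingly expected to give about 5000 nM, within 2000 nM to 15000 nM.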

Compound 4, half-maximal effective concentration: 4700 nM
The estimate for compound 4 lay 1.1-fold (0.03 log units) above the measured number, and the stated range covers the measured number.
By their numbers in this assay, from the lowest: compounds 1, 4, 3 and 2 (each within the scatter of the next).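

In this assay, the aromatic carbon next to the ring atom that bears a carboxy group now also carries a nitro-substituted aryl group, and all three new steps stay within the scatter: 2-nitrophenyl for 3-chloro-2-methylphenyl (a 1.1-fold lower number from compound 3 to compound 4 (0.04 log units; within the scatter)), nitro for methyl (a 1.2-fold lower number from compound 2 to compound 4 (0.07 log units; within the scatter)) and 2-nitrophenyl for 4-methylphenyl (a 1.2-fold higher number from compound 1 to compound 4 (0.09 log units; within the scatter)). The entering 2-nitrophenyl brings hydrogen-bond acceptors and a double bond outside aromatic rings, neither of which 3-chloro-2-methylphenyl has, yet the numbers remain within the scatter of one another. No measurement available here explains why the four numbers lie so close together.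

As far as these compounds go, it remains open whether an aryl group bearing an amine or a carboxylic acid would stay within the scatter at this position. From the compounds shown here alone, a plain alkyl chain in place of the aryl group is equally open.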